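Replacing the sulfur-linked ring of compound 3 with a piperazine

A few compounds are considered here, and "the series" means these few. Any claim that something is new, unique, unknown or untested is made for them only; others in the source may bear on it.

Three compounds share one core and differ only in the group attached to the sulfur of the side chain. Compound 1 `Cn1cnnc1SCC(=O)Nc1ccc(-c2nc(-c3ccccc3)c(-c3ccccc3)n2C)cc1` gives 88% in a functional assay on HT-29 cells (Homo sapiens) for cytotoxicity, read by MTT assay, with a stated time of 24 h, tested at 80 ug/mL; a lower number here means a weaker effect, a higher number a stronger effect of the compound at the concentration tested. Compound 2 `Cc1nnc(SCC(=O)Nc2ccc(-c3nc(-c4ccccc4)c(-c4ccccc4)n3C)cc2)s1` gives 90.5% in this assay, a change of a number 2.5 percentage points higher from compound 1 to compound 2 (within the scatter). Compound 3 `Cn1c(-c2ccc(NC(=O)CSC3=NCCS3)cc2)nc(-c2ccccc2)c1-c1ccccc1` gives 75.2% in this assay, the lowest of the three numbers; the changes were a number 12.8 percentage points lower from compound 1 to compound 3 (beyond the scatter) and a number 15.3 percentage points lower from compound 2 to compound 3 (beyond the scatter), both modest but beyond the scatter.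

Compound 4 `CN(C)/C=C/N1CCN(CC(=O)Nc2ccc(-c3nc(-c4ccccc4)c(-c4ccccc4)n3C)cc2)CC1` has not yet been measured. Compared with compound 3, the change is a group of 11 heavy atoms (8 carbon, 3 nitrogen; one six-membered non-aromatic ring with 2 hetero atoms) in place of a group of 6 heavy atoms (3 carbon, 1 nitrogen, 2 sulfur; one five-membered non-aromatic ring with 2 hetero atoms), on a saturated chain carbon bound to a carbonyl carbon. Among the compounds with values here, no measured step touches this kind of change: all three measured steps only exchanged the ring that sits on the sulfur, whereas here the sulfur and its ring leave together and a nitrogen ring enters in their place. The measured steps show that the numbers in this assay moved only modestly across this small set, so a step of similar size or smaller seems plausible, in either direction. The expected step from compound 3 to compound 4 is therefore a number 0.8 percentage points higher from compound 3 to compound 4 (within the scatter), within the scatter. For compound 4 in this assay the estimate is 76%, with a range from 58% to 92%.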

Compound 4, a percentage reported as activity, at one concentration (the size of the read-out at that concentration, not a potency): 45.4%
The estimate for compound 4 lay 30.6 percentage points above the measured number; measured number below the stated range.
By their numbers in this assay, from the lowest: compound 4; then compound 3; then compounds 1 and 2 (each within the scatter of the next).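

Taking the sulfur away together with its ring and placing 4-(2-(dimethylamino)ethenyl)piperazin-1-yl on the saturated chain carbon bound to a carbonyl carbon has a far clearer effect in this assay than any exchange of one ring on the sulfur for another: the steps are a number 29.8 percentage points lower from compound 3 to compound 4 (beyond the scatter), a number 42.6 percentage points lower from compound 1 to compound 4 (beyond the scatter) and a number 45.1 percentage points lower from compound 2 to compound 4 (beyond the scatter). The position therefore tolerates some ring exchanges on the sulfur, yet it is not indifferent to what is attached, and compound 4 now has the lowest number of the four compounds, with its step to each of the others beyond the scatter. No measurement available here bears on why the number fell.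

Several things changed at once in compound 4, so the compounds shown leave open whether the drop follows the loss of the sulfur, the arrival of the piperazine ring or the dimethylamino-bearing ethenyl group on it. A plain piperazine, a 4-methylpiperazine or a morpholine on the same chain carbon would help to separate these parts.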